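A few compounds are considered here, and "the series" means these few. Any claim that something is new, unique, unknown or untested is made for them only; others in the source may bear on it.

Compound 1 `Cc1ccc(NC(=O)COc2ccc3cc(/C=C4/SC(=O)NC4=O)ccc3c2)cc1`: 9000 nM
Compound 2 `O=C(COc1ccc2cc(/C=C3/SC(=O)NC3=O)ccc2c1)Nc1ccc(Br)cc1F`: > 50000 nM
Compound 3 `Cc1cc(Br)ccc1NC(=O)COc1ccc2cc(/C=C3/SC(=O)NC3=O)ccc2c1`: 7400 nM

All three compounds share one core and differ only in the aromatic group attached to the amide-type nitrogen. In an assay on isolated protein for inhibition of histone deacetylase 8 (Homo sapiens), with a stated time of 1 h (on this read-out lower numbers stand for stronger inhibition and higher numbers for weaker inhibition), compound 1 gives 9000 nM, the highest of the two measured numbers. Compound 3 sits close to it, since a 1.2-fold lower number from compound 1 to compound 3 (0.09 log units; within the scatter). For compound 2 the assay gives only a limit, not a number (the limit of > 50000 nM in this assay, at which 1 of the 3 values shown sits). The two steps involving that compound are therefore read as limits: an at least 5.5-fold higher number from compound 1 to compound 2 (0.74 log units; beyond the scatter), and an at least 6.7-fold lower number from compound 2 to compound 3 (0.82 log units; beyond the scatter).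

Compound 4 `Cc1cccc2sc(NC(=O)COc3ccc4cc(/C=C5/SC(=O)NC5=O)ccc4c3)nc12` has not yet been measured. It alters compound 1 at the same place as the other two: 4-methyl-1,3-benzothiazol-2-yl in place of 4-methylphenyl on an amide-type nitrogen. The measured steps at this position show that one swap leaves the number unchanged while another pushes it past the upper limit of the assay, so a change of the group here can be harmless or costly. The entering group is larger and differs more from compound 1 than either measured swap, which makes the outcome uncertain. The step expected is a 1.3-fold higher number from compound 1 to compound 4 (0.12 log units; within the scatter). The estimate for compound 4 is 12000 nM, expected to fall between 3000 nM and 50000 nM.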

Compound 4, half-maximal inhibitory concentration: 5800 nM
Estimate against measurement, compound 4: 2.1-fold (0.32 log units) above; the measured number falls inside the stated range.
By their numbers in this assay, from the lowest: compounds 4, 3 and 1 (each within the scatter of the next). At a limit, above all of these: compound 2.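

In this assay, this position on the amide-type nitrogen accepts more than a swap of small groups on the phenyl ring. The larger 4-methyl-1,3-benzothiazol-2-yl, which brings a second aromatic ring along with nitrogen and sulfur, leaves the result within the scatter of both compound 1 (a 1.6-fold lower number from compound 1 to compound 4 (0.19 log units; within the scatter)) and compound 3 (a 1.3-fold lower number from compound 3 to compound 4 (0.11 log units; within the scatter)), so the added ring brings neither a clear gain nor a clear loss. Compound 2 remains the only clear outlier (an at least 8.6-fold lower number from compound 2 to compound 4 (0.93 log units; beyond the scatter)), and this step rests on a limit rather than a number: the limit of > 50000 nM in this assay, at which 1 of the 4 values shown sits.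

It remains open why the fluoro group of compound 2 is so much worse than the methyl group of compound 3. It is also unknown how this position would respond to an amine or a carboxylic acid on the aromatic group.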